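The source may hold more compounds than are shown below. What is called first, only, known or untested is meant among the compounds shown, and "the series" means these compounds.

Of the compounds shown here, two have been measured in a functional assay on HeLa cells (Homo sapiens) for cytotoxicity, read by MTT assay, with a stated time of 72 h, tested at 10 uM; a higher number here means more inhibition of growth at the concentration tested, a lower number less inhibition of growth. Compound 1 `N/C(=N\NC(=S)N1CCOCC1)c1ccccn1` gives 56.3% in this assay. For the measured compounds named here, compound 2 `Cc1cccc(/C(N)=N/NC(=S)N2CCSCC2)n1` gives 67.6% in this assay, the higher of the two numbers, and its only neighbour, compound 1, stands lower by a gap that goes beyond the usual scatter. Going by the values given here, these two compounds differ in more than one place, so their pair offers no single isolated step; their values show only that compound 2 is the higher of the two.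

Compound 3 `Cc1cccc(/C(N)=N/NC(=S)N2CCOCC2)n1` now comes into view. It differs from compound 2 by morpholin-4-yl in place of thiomorpholin-4-yl on a thiocarbonyl carbon. Among the compounds with values here, no measured pair isolates this exchange, so the expected size of the step rests on thin ground. The step of a number 7.6 percentage points lower from compound 2 to compound 3 (within the scatter) is expected to be small, downward if anything, and not clearly beyond the scatter. For compound 3 the estimate in this assay is 60%, within a range from 45% to 75%.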

Compound 3, percent growth inhibition at one concentration: 85.4%
Beside the measured number, compound 3's estimate is 25.4 percentage points below it; measured number above the stated range.
By their numbers in this assay, from the lowest: compound 1; then compound 2; then compound 3.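

Read in this assay, the exchange on a thiocarbonyl carbon now stands alone: morpholin-4-yl in place of thiomorpholin-4-yl gives a number 17.8 percentage points higher from compound 2 to compound 3 (beyond the scatter), so this position responds to a single hetero atom change in the ring, and the step runs upward. With morpholin-4-yl held fixed, methyl in place of hydrogen on an aromatic carbon gives a number 29.1 percentage points higher from compound 1 to compound 3 (beyond the scatter), which isolates a second change that the pair of compound 1 and compound 2 could not separate. Nothing at hand explains either step.

Going by these compounds, whether the methyl step holds equally with thiomorpholin-4-yl on the thiocarbonyl carbon remains open. So does how piperidin-1-yl or 4-methylpiperazin-1-yl would compare at that position, and how an ethyl group would compare with the methyl on the aromatic carbon.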